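Dihydropyridine aryloxy side chains: anti-edema series notes

The compounds below may be only part of what the source reports. "The series", "measured", "known", "first", "only" and "open" are said of these compounds alone.

Measured so far:
- Compound 1 `CCOC(=O)C1=C(C)NC(C)=C(C(=O)OCC)C1c1ccc(OCC(=O)NCc2ccccc2)cc1`: 8.9%
- Compound 2 `CCOC(=O)C1=C(C)NC(C)=C(C(=O)OCC)C1c1ccc(OCC(=O)Nc2c(C)cccc2C)cc1`: 47.8%
- Compound 3 `CCOC(=O)C1=C(C)NC(C)=C(C(=O)OCC)C1c1ccc(OCC(=O)NNC(=O)c2ccccc2)cc1`: 44.5%

Read-out throughout is a functional assay on the whole organism (strain Wistar) for inhibition, with Rattus norvegicus as the target, read by paw edema, with stated times of 30 min and 2 h, at a dose of 20 mg/kg; a higher number here means more inhibition at the dose given (going by the name of the read-out), a lower number less inhibition. Compound 3 sits second highest of the three: its value and that of compound 2 lie within the scatter of each other (a number 3.3 percentage points lower from compound 2 to compound 3 (within the scatter)), while compound 1 is far lower (a number 35.6 percentage points higher from compound 1 to compound 3 (beyond the scatter)). The other large step, a number 38.9 percentage points higher from compound 1 to compound 2 (beyond the scatter), likewise shows the benzyl amide as the odd one out.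

Compound 4 `CCOC(=O)C1=C(C)NC(C)=C(C(=O)OCC)C1c1ccc(OCc2nnc(S)o2)cc1` carries 5-sulfanyl-1,3,4-oxadiazol-2-yl in place of benzamidocarbamoyl on a saturated chain carbon bound to an oxygen on an aromatic ring. Among the compounds with values here, no measured step changes this part of the side chain in a comparable way; the three steps only replace groups on the amide nitrogen, and the amide itself remains in every measured compound. Hence no step bears directly on compound 4, and the expectation is wide. Compound 4 is estimated at 35%, range 10% to 55%, an expected step of a number 9.5 percentage points lower from compound 3 to compound 4 (within the scatter), within the scatter as a central guess.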

Compound 4, a percentage reported as inhibition, in the whole organism at one dose (the size of the read-out at that dose, not a potency): 61.7%
For compound 4 the middle estimate is 26.7 percentage points below the measured one; measured number above the stated range.
By their numbers in this assay, from the lowest: compound 1; then compounds 3 and 2 (each within the scatter of the next); then compound 4.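

In this assay the 5-sulfanyl-1,3,4-oxadiazol-2-yl group on the saturated chain carbon gives a number 17.2 percentage points higher from compound 3 to compound 4 (beyond the scatter) and a number 13.9 percentage points higher from compound 2 to compound 4 (beyond the scatter) and a number 52.8 percentage points higher from compound 1 to compound 4 (beyond the scatter) with the amide gone. Within the data shown here, the earlier steps changed only the group on the amide nitrogen, so this is the first sign that the amide is not needed for inhibition in these compounds. Nothing available explains this step.

Open, on these data alone, is whether the sulfanyl group or the five-membered aromatic ring carries the step. A methyl group in place of sulfanyl, or a carboxylic acid on the same chain carbon, would help separate these.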